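This account rests on a few compounds, and the source may have more. Where it says the series, first, only, none or still open, it means among the compounds named here.

Measured so far:
- compound 1, `CC(=O)Nc1ccc2ncnc(Nc3ccc(F)c(Cl)c3)c2c1`: 225 nM in a functional assay on PC-9 cells (Homo sapiens) for antiproliferative activity, read by luminescence, with a stated time of 72 h; a lower number here means a stronger inhibitor, a higher number a weaker inhibitor
- compound 2, `CC(=O)Nc1ccc2ncnc(Nc3ccc(OCc4cccc(F)c4)c(Cl)c3)c2c1`: 662 nM in this assay

For the measured compounds named here, compound 2 holds the highest of the two numbers; its nearest neighbour is compound 1, and the only step in the set, a 2.9-fold higher number from compound 1 to compound 2 (0.47 log units; beyond the scatter), is modest but beyond the scatter.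

Compound 3, `Fc1cccc(COc2ccc(Nc3ncnc4ccc(NC(=S)NCCN5CCCCC5)cc34)cc2Cl)c1`, is not yet measured. Against compound 2 it differs by a group of 11 heavy atoms (8 carbon, 2 nitrogen, 1 sulfur; one six-membered non-aromatic ring with 1 hetero atom) in place of a group of 3 heavy atoms (2 carbon, 1 oxygen; no ring), on a nitrogen on an aromatic ring. Going by the values given here, no measured step touches this position: the one step known concerns the (3-fluorobenzyl)oxy group on the other ring, so it gives no reading of direction or size here. With nothing to anchor the change, the expectation is for no step beyond the scatter, with a wide range either way.

The number for compound 3 is estimated at 450 nM (range 110 nM to 1800 nM), which would mean an expected step of a 1.5-fold lower number from compound 2 to compound 3 (0.17 log units; within the scatter).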

Compound 3, half-maximal inhibitory concentration: 2160 nM
For compound 3 the middle estimate is 4.8-fold (0.68 log units) below the measured one, and the stated range ends below it.
By their numbers in this assay, from the lowest: compound 1; then compound 2; then compound 3.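

In this assay, for the compounds shown here, this is the first reading at the aromatic nitrogen: replacing acetyl with the group of 11 heavy atoms, which carries sulfur and a six-membered non-aromatic ring, gives a 3.3-fold higher number from compound 2 to compound 3 (0.51 log units; beyond the scatter), a modest change beyond the scatter toward a weaker inhibitor. The position therefore responds to substitution, and this much larger group still leaves a measurable number in the assay. Nothing shown explains the loss, and this single step cannot separate the contributions of the sulfur, the chain and the ring.

Still open, from the compounds shown here alone, is whether an oxygen in place of the sulfur, a shorter chain or a morpholine ring in place of the six-membered ring would move the number. Also open, going by these compounds, is whether the same change gives a similar step with fluoro in place of the (3-fluorobenzyl)oxy group.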